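The compounds below may be only part of what the source reports. "The series", "measured", "known", "first", "only" and "open" are said of these compounds alone.

Measured set:
Compound 1, `C/C(=C\COC(=O)Nc1ccccc1)C1=CC(=O)C(C)(C)O1`. In a functional assay on FM3A cells (Mus musculus) for inhibition (on this read-out higher numbers stand for weaker inhibition and lower numbers for stronger inhibition), compound 1 gives only a limit, > 200 ug/mL.
Compound 2, `C/C(=C\COC(=O)NC(C)C)C1=CC(=O)C(C)(C)O1`. In this assay compound 2 gives 7.2 ug/mL.
Compound 3, `COc1ccc(/C=C/C=C(\C)C2=CC(=O)C(C)(C)O2)cc1`. In this assay compound 3 gives 25 ug/mL.

Compound 3 holds the highest of the two numbers; its nearest neighbour, compound 2, gives a lower number, beyond the scatter. The remaining value, that of compound 1, is a limit of the assay (the limit of > 200 ug/mL in this assay, at which 1 of the 3 values shown sits).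

Compound 4, `C/C(=C\C=C\c1ccccc1)C1=CC(=O)C(C)(C)O1`, differs from compound 3 by hydrogen in place of methoxy on an aromatic carbon. Going by the values given here, the only measured step, an at least 27-fold lower number from compound 1 to compound 2 (1.44 log units; beyond the scatter), concerns the group on the amide-type nitrogen and does not touch the aromatic ring, so no measured step bears on this change. In this assay no step beyond the scatter is therefore expected; the expected step is a 1.2-fold higher number from compound 3 to compound 4 (0.08 log units; within the scatter). Compound 4 is estimated at 30 ug/mL, within 8 ug/mL to 120 ug/mL.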

Compound 4, half-maximal inhibitory concentration: 15 ug/mL
The estimate for compound 4 lay 2.0-fold (0.30 log units) above the measured number, and the stated range covers the measured number.
By their numbers in this assay, from the lowest: compound 2; then compounds 4 and 3 (each within the scatter of the next). At a limit, above all of these: compound 1.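

In this assay, hydrogen in place of methoxy on the aromatic carbon gives a 1.7-fold lower number from compound 3 to compound 4 (0.22 log units; within the scatter). Going by these compounds alone, this is the first reading on the aromatic ring: at this place, para to a large group, the methoxy can be lost without a change beyond the scatter. Nothing shown gives a reason for the size of this step.

Going by these compounds, whether an amine or a carboxylic acid at this place would move the read-out beyond the scatter stays open. Compound 2 and compound 4 differ in more than one place, so their side chains cannot be compared directly.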